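The source may hold more compounds than are shown below. What is called first, only, known or untested is meant among the compounds shown, and "the series" means these compounds.

Series notes. In an assay on isolated protein for inhibition of Aromatase (Homo sapiens), read by fluorescence and colorimetric assay, with a stated time of 30 min (on this read-out higher numbers stand for weaker inhibition and lower numbers for stronger inhibition), compound 1 `c1ccc(C(c2ccccc2)n2ccnn2)cc1` gives 4580 nM, compound 2 `CCCCCCCc1cn(C(c2ccccc2)c2ccccc2)nn1` gives 19400 nM and compound 3 `c1ccc(C(c2ccccc2)n2cc(C3CCCCC3)nn2)cc1` gives 13700 nM. Compound 3 stands second highest of the three numbers; a 1.4-fold lower number from compound 2 to compound 3 (0.15 log units; within the scatter) lies within the scatter, whereas a 3.0-fold higher number from compound 1 to compound 3 (0.48 log units; beyond the scatter) lies beyond it. Compound 4 `c1ccc(OCc2cn(C(c3ccccc3)c3ccccc3)nn2)cc1` differs from compound 3 in one place: phenoxymethyl in place of cyclohexyl on an aromatic carbon. Going by the values given here, the steps that bear on this are a 4.2-fold higher number from compound 1 to compound 2 (0.63 log units; beyond the scatter) and a 3.0-fold higher number from compound 1 to compound 3 (0.48 log units; beyond the scatter), both modest rises when a large group replaces hydrogen on an aromatic carbon, while a 1.4-fold lower number from compound 2 to compound 3 (0.15 log units; within the scatter) shows that exchanging one large group for another changes little. The number for compound 4 is therefore expected to shift only slightly, with a 1.1-fold lower number from compound 3 to compound 4 (0.02 log units; within the scatter) falling within the scatter. The estimate for compound 4 in this assay is 13000 nM, ranging from 5500 nM to 30000 nM.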

Compound 4, half-maximal inhibitory concentration: 31300 nM
Beside the measured number, compound 4's estimate is 2.4-fold (0.38 log units) below it; measured number outside the range, above it.
By their numbers in this assay, from the lowest: compound 1; then compounds 3, 2 and 4 (each within the scatter of the next, the first and the last beyond it).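

In this assay, exchanging one large group for another on this aromatic carbon can matter: a 2.3-fold higher number from compound 3 to compound 4 (0.36 log units; beyond the scatter) goes beyond the scatter, unlike the earlier exchange of heptyl for cyclohexyl. By contrast, a 1.6-fold higher number from compound 2 to compound 4 (0.21 log units; within the scatter) stays within the scatter, and a 6.8-fold higher number from compound 1 to compound 4 (0.83 log units; beyond the scatter) leaves the hydrogen of compound 1 with the lowest number of the four. No available evidence accounts for these shifts. Still open, going by these compounds, is whether a methyl group, an amine or a carboxylic acid at this position would bring the number back toward that of compound 1.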